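Phenyl extension at the oxygen ring: expectation for compound 4

The source may report more compounds than this note shows. Statements on the series, on what has been measured and on what is new or still open speak of the compounds shown alone.

Three compounds have numbers in a functional assay on BE(2)-C cells (Homo sapiens) for inhibition, read by MTT assay, with a stated time of 72 h; on this read-out higher numbers stand for weaker inhibition of growth and lower numbers for stronger inhibition of growth. Compound 1 `N#C/C(=C\c1c(F)c(F)c(F)c(F)c1F)C(=O)c1ccc[nH]1` gives 14000 nM, compound 2 `N#C/C(=C\c1c(F)c(F)c(F)c(F)c1F)C(=O)c1c[nH]c2ccccc12` gives 10000 nM, and compound 3 `COc1ccc(CNC(=O)/C(C#N)=C/c2ccco2)cc1` gives 24000 nM. Compound 3 has the highest number of the three; the gap to compound 1 lies within the scatter, while the gap to compound 2 lies beyond it. Compound 4 `COc1ccc(CNC(=O)/C(C#N)=C/c2ccc(-c3ccccc3)o2)cc1` differs from compound 3 by phenyl in place of hydrogen on an aromatic carbon. Going by the values given here, no measured pair shows this change, so its size is unknown. A step of a 2.0-fold lower number from compound 3 to compound 4 (0.30 log units; within the scatter) toward a lower number is expected, of a size that may not exceed the scatter. For compound 4 the estimated value in this assay is 12000 nM, with a range from 4000 nM to 40000 nM.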

Compound 4, concentration for 50% growth inhibition: > 100000 nM
Compound 4 ended at the assay's limit (the forecaster's own chance of this, stated with the estimate: 15%); middle value at least 8.3-fold (0.92 log units) away from the limit.
By their numbers in this assay, from the lowest: compounds 2, 1 and 3 (each within the scatter of the next, the first and the last beyond it). At a limit, above all of these: compound 4.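

In this assay, phenyl in place of hydrogen on an aromatic carbon, next to the ring oxygen, gives an at least 4.1-fold higher number from compound 3 to compound 4 (0.61 log units; beyond the scatter). Going by these compounds alone, this is the first reading at this position, and it shows that this change weakens growth inhibition rather than strengthening it. The result for compound 4 is a limit and not a number: the limit of > 100000 nM in this assay, at which 1 of the 4 values shown sits.

From the compounds shown here alone, whether a methyl group or a chlorine atom on this carbon would keep the growth inhibition of compound 3 remains open. So does whether an amine on the added phenyl would recover any of it.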